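The source may report more compounds than this note shows. Statements on the series, on what has been measured and on what is new or still open speak of the compounds shown alone.

Measured so far:
- compound 1, `COc1cc(N)c(Cl)cc1C(=O)CCC1CCN(CCNS(=O)(=O)c2ccc(NC(C)=O)cc2)CC1`, 7% in an assay on HEK293 cells for displacement of a labelled ligand from 5-hydroxytryptamine receptor 6 (Homo sapiens), with a stated time of 60 min, tested at 0.01 uM, in the presence of a further agent that is not named here; a lower number here means a weaker effect, a higher number a stronger effect of the compound at the concentration tested
- compound 2, `COc1ccc(S(=O)(=O)CCCN2CCC(CCC(=O)c3cc(Cl)c(N)cc3OC)CC2)cc1`, 10% in this assay

Both numbers come from this assay, and both are small. Compound 1 gives 7%, the lower of the two numbers, and compound 2 gives 10%, a number only a few points apart from it, so the two compounds cannot be told apart within the usual scatter of this measurement. Among the compounds with values here, no step between two measured compounds that differ in a single place is available, so the effect of any one structural change has not been seen directly.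

Compound 3, `COc1cc(N)c(Cl)cc1C(=O)CCC1CCN(CCNS(=O)(=O)c2ccc(N)c(Br)c2)CC1`, has not been measured. It differs from compound 1 in one place: 4-amino-3-bromophenyl in place of 4-acetamidophenyl on a sulfonyl sulfur. Within the data shown here, since there is no measured step to lean on, the expectation rests only on the shared core of compound 1 and the small number of compound 1 itself.

The step from compound 1 to compound 3 is estimated as a number 5 percentage points higher from compound 1 to compound 3 (within the scatter), a change expected to stay within the scatter rather than a clear rise or fall. Compound 3 is therefore expected to give about 12%, estimated to lie between 0% and 35%.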

Compound 3, a percentage reported as inhibition, at one concentration (the size of the read-out at that concentration, not a potency): 39%
Compound 3: middle estimate off by 27 percentage points, on the low side, outside the stated range (above it).
By their numbers in this assay, from the lowest: compounds 1 and 2 (each within the scatter of the next); then compound 3.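

Within the data shown here, the group on the sulfonyl sulfur is the first place where a single change is seen to move the read-out: in this assay, 4-amino-3-bromophenyl in place of 4-acetamidophenyl gives a number 32 percentage points higher from compound 1 to compound 3 (beyond the scatter). Among these compounds, the earlier compounds offered no step of this kind, so this is the first direct sign that the read-out at this concentration depends on what sits at this position. The change is a double one, however, since the acetyl part of the acetamido group leaves and a bromine enters, and nothing available here accounts for the rise.

Among the compounds shown here, the single step cannot separate these two parts, so it remains open what a phenyl ring carrying only the amino group would give, and what one carrying both the acetamido group and the bromine would give. It also leaves open whether the bromine can be exchanged for another atom or group, such as chlorine or a methyl group, and because the read-out comes from one concentration, it gives no potency for any of these compounds.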